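Hydroxamate series: acyl group at the amide nitrogen

The compounds below may be only part of what the source reports. "The series", "measured", "known", "first", "only" and "open" are said of these compounds alone.

Measured compounds:
compound 1, `O=C(CCCCCC(NC(=O)c1ccco1)C(=O)NCc1ccccc1)NO`, 4600 nM
compound 2, `O=C(CCCCC[C@H](NC(=O)c1cc2ccccc2[nH]1)C(=O)NCc1ccccc1)NO`, 1260 nM

Both compounds carry the same hydroxamate chain and benzylamide, and differ in the acyl group on the amide nitrogen. In a functional assay on NFF cells (Homo sapiens) for antiproliferative activity (on this read-out lower numbers stand for stronger inhibition and higher numbers for weaker inhibition), compound 1 gives 4600 nM, and compound 2 gives 1260 nM, the lower of the two numbers; the gap between them lies beyond the usual scatter, so compound 2 stands as the stronger inhibitor of the pair on the numbers at hand.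

Compound 3, `O=C(CCCCC[C@H](NC(=O)c1cccs1)C(=O)NCc1ccccc1)NO`, is not yet measured. Relative to compound 2 the change is thiophen-2-yl in place of 1H-indol-2-yl on a carbonyl carbon. The entering group is a single five-membered ring, while the leaving group carries an additional six-membered ring; compound 1, whose acyl group is also a single five-membered ring, gives the higher number.

The step from compound 2 to compound 3 is expected to go toward weaker inhibition, by a 2.8-fold higher number from compound 2 to compound 3 (0.44 log units; beyond the scatter), beyond the scatter. Compound 3 is estimated at 3500 nM, within a range of 1500 nM to 8000 nM, because compound 1 gives 4600 nM.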

Compound 3, half-maximal inhibitory concentration: 5200 nM
Compound 3: middle estimate off by 1.5-fold (0.17 log units), on the low side, and the stated range covers the measured number.
By their numbers in this assay, from the lowest: compound 2; then compounds 1 and 3 (each within the scatter of the next).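

Within the data shown here, with the hydroxamate chain and benzylamide held fixed, thiophen-2-yl in place of 1H-indol-2-yl on a carbonyl carbon gives, in this assay, a 4.1-fold higher number from compound 2 to compound 3 (0.62 log units; beyond the scatter) and this is the only single-place step at this position so far. The change removes the six-membered aromatic ring and the hydrogen-bond donor and replaces the ring nitrogen with sulfur, all at once, and this one step does not separate those differences. No measurement available here explains the higher number for compound 3.

From the compounds shown here alone, it remains open whether the six-membered ring, the ring hydrogen on nitrogen, or the hetero atom itself carries the difference between compound 2 and compound 3. A 1H-pyrrol-2-yl acyl group would keep that nitrogen hydrogen without the six-membered ring and a benzothiophen-2-yl acyl group would keep both rings with sulfur in place of that nitrogen hydrogen, so either could pull these features apart.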